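Chloro Added to Two Cores That Sit at the Limit

This account rests on a few compounds, and the source may have more. Where it says the series, first, only, none or still open, it means among the compounds named here.

Compound 1, `Cc1cc(C)nc(SCc2cc(=O)c3cc(Cl)ccc3o2)n1`: in a functional assay on MDA-MB-435S cells (Homo sapiens) for cytotoxicity, read by MTT assay, with a stated time of 72 h (a lower number here means a stronger inhibitor, a higher number a weaker inhibitor), compound 1 gives > 25000 nM, which is a limit of the assay and not a number.
Compound 2, `Cc1cc(C)nc(SCc2cc(=O)c3ccccc3o2)n1`: compound 2 gives > 25000 nM, again a limit.
Compound 3, `Nc1nnc(SCc2cc(=O)c3ccccc3o2)s1`: compound 3 gives > 25000 nM, also a limit.

All three measured compounds thus share one fate, summed up by the limit of > 25000 nM in this assay, at which 3 of the 3 values shown sit. The step that the two limits leave unreadable from compound 2 to compound 1 is the change (chloro in place of hydrogen on an aromatic carbon); with both ends at the limit, its size cannot be read. How the core of compound 2 differs from the core of compound 3 is not broken down here. Compound 4, `Nc1nnc(SCc2cc(=O)c3cc(Cl)ccc3o2)s1`, is the not yet measured partner of compound 3, carrying (chloro in place of hydrogen on an aromatic carbon), the same change, at a place described in the same words. For compound 4 the expected step is a step that the limit leaves unreadable from compound 3 to compound 4, resting on the fact that the matching step that the two limits leave unreadable from compound 2 to compound 1 moved nothing readable. Compound 4 is therefore estimated at 40000 nM, most likely reported only as a limit, within 15000 nM to 120000 nM.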

Compound 4, half-maximal inhibitory concentration: > 25000 nM
Compound 4: no number, only a limit; the forecaster's own chance of this, stated with the estimate: 85%; the middle value does not contradict the limit.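

Compound 3 and compound 4 both end at a limit of the assay and not at a number, so no new step can be read from this result. The compounds shown leave open whether chloro in place of hydrogen, or the difference between the two cores, changes cytotoxicity at all, and all of them share one result: the limit of > 25000 nM in this assay, at which 4 of the 4 values shown sit.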